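Nitrile to primary amide on the aminoalkyl chain

The source may report more compounds than this note shows. Statements on the series, on what has been measured and on what is new or still open speak of the compounds shown alone.

Compound 1 `Cc1c(C(C)C)c(=O)on1C(=O)N(C)Cc1ccc(F)cc1` gives 111 nM in an assay (strain Wistar) for inhibition of Hormone-sensitive lipase (Rattus norvegicus), read by spectrophotometry (on this read-out higher numbers stand for weaker inhibition and lower numbers for stronger inhibition), and compound 2 `Cc1c(C(C)C)c(=O)on1C(=O)N(C)Cc1ccco1` gives 4 nM. Compound 3 `Cc1c(C(C)C)c(=O)on1C(=O)N(C)CCC#N` reaches only the limit of this assay, > 1000 nM, which is a limit and not a number (the limit of > 1000 nM in this assay, at which 1 of the 3 values shown sits). Both measured steps onto compound 3 run the same way: an at least 9.0-fold higher number from compound 1 to compound 3 (0.95 log units; beyond the scatter) and an at least 250-fold higher number from compound 2 to compound 3 (2.39 log units; beyond the scatter). Compound 4 `Cc1c(C(C)C)c(=O)on1C(=O)N(C)CC(N)=O` differs from compound 3 by carbamoyl in place of cyanomethyl on a saturated chain carbon bound to an amide-type nitrogen. Among the measured compounds shown here, no measured step changes cyanomethyl to carbamoyl, so the size of this step is unknown, and the starting point is itself a limit. Compound 4 is therefore expected to stay at a weak level, with a step that the limit leaves unreadable from compound 3 to compound 4 as the assumed step, most likely again at the limit. The expected value for compound 4 is 2000 nM, within 500 nM to 10000 nM.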

Compound 4, half-maximal inhibitory concentration: > 1000 nM
Compound 4: only a limit was reported; the forecaster's own chance of this, stated with the estimate: 60%; the middle value does not contradict the limit.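

In this assay compound 4 gives > 1000 nM, which is a limit and not a number. Replacing the ring groups with carbamoyl gives an at least 250-fold higher number from compound 2 to compound 4 (2.39 log units; beyond the scatter) and an at least 9.0-fold higher number from compound 1 to compound 4 (0.95 log units; beyond the scatter), so carbamoyl, like cyanomethyl, stays well short of furan-2-yl and 4-fluorophenyl at this position. The step between compound 3 and compound 4 cannot be read, and the two compounds share the same limit: the limit of > 1000 nM in this assay, at which 2 of the 4 values shown sit.

Going by these compounds, how far either compound lies beyond that limit remains open. Also open, on these data alone, is whether a ring-free group such as an amine or a carboxylic acid, or a longer chain carrying the carbamoyl, would come closer to the ring-bearing compounds.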